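A few compounds are considered here, and "the series" means these few. Any claim that something is new, unique, unknown or untested is made for them only; others in the source may bear on it.

Measured in an ADME assay on a cell-free system (serum) for metabolic stability; a higher number here means that the compound lasts longer, a lower number that the compound disappears faster:
Compound 1 `COc1ccccc1C(=O)Oc1ccc(O)c(C(C)(C)C)c1`: < 0.25 h
Compound 2 `CC(C)(C)c1cc(NC(=O)c2ccc(Cl)cc2Cl)ccc1O`: > 1 h

The result for compound 1 is a limit. Compound 2 also gives only a limit, > 1 h, and it is the higher of the two values shown. Compound 3 `CC(C)(C)c1cc(NC(=O)c2ccc(Cl)cc2Cl)cc(C(C)(C)C)c1O` differs from compound 2 by tert-butyl in place of hydrogen on an aromatic carbon, ortho to a hydroxy group (tert-butyl in place of hydrogen on an aromatic carbon). Among the compounds with values here, no measured pair of compounds shows this change in this assay. A small lengthening of the half-life is expected, with an estimated step that the limit leaves unreadable from compound 2 to compound 3, hardly beyond the scatter. For compound 3 the estimated half-life is 2 h, within an expected range of 1 h to 6 h.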

Compound 3, half-life: > 1 h
Compound 3 ended at the assay's limit (the forecaster's own chance of this, stated with the estimate: 75%); the middle value does not contradict the limit.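

In this assay compound 2 gives only a limit, > 1 h. Within the data shown here, compound 3 also gives only a limit, > 1 h, and no step between them can be read. The compounds shown leave open whether tert-butyl in place of hydrogen changes the half-life at all.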